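A few compounds are considered here, and "the series" means these few. Any claim that something is new, unique, unknown or untested is made for them only; others in the source may bear on it.

Compound 1 `O=C(Cn1cc(C(=O)O)nn1)NCc1ccccc1` carries a carboxy group on its triazole ring, and in an ADME assay on cells (spleen, Mus musculus, strain C57BL/6) for inhibition, read by flow cytometry and propidium iodide staining, with a stated time of 24 h, at 37 degrees C (a lower number here means that less compound is needed, a higher number that more compound is needed for the effect), compound 1 is reported only as "non-toxic" (no number reported), with no single number. Its standing against the other measured compounds therefore cannot be placed on a scale: compound 3 `O=C(Cn1cc(-c2ccccc2C(F)(F)F)nn1)NCc1ccccc1` likewise gives "non-toxic" (no number reported) in this assay, again without a number, while compound 2 `O=C(Cn1cc(-c2ccc([N+](=O)[O-])cc2)nn1)NCc1ccccc1` is the one entry with a figure, giving 800 uM in this assay. Compound 4 `O=C(Cn1cc(-c2cccc(F)c2)nn1)NCc1ccccc1` has not yet been measured. It differs from compound 1 as follows: 3-fluorophenyl in place of carboxy on an aromatic carbon. For the measured compounds named here, no step between measured compounds is available to guide the size of this change, so nothing can be said about direction beyond the scatter of this assay; the only anchor is that compound 2 sits at a high concentration and two others show no effect at all. Compound 4 is accordingly expected to fall in this assay near 800 uM, within a range of 300 uM to 2000 uM, with a fair chance that it, too, is reported without a number.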

Compound 4, concentration for half-maximal effect: "non-toxic" (no number reported)
The entry for compound 4 holds no number; no gap can be computed for the estimate.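

In this assay compound 1 gives "non-toxic" (no number reported) and compound 4 gives "non-toxic" (no number reported) without a single number, so no step can be read between them. The compounds shown leave open whether 3-fluorophenyl in place of carboxy shifts this read-out at all, and no supporting evidence bears on this result.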